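Chain extension on the side chain of compound 3

The source may hold more compounds than are shown below. What is called first, only, known or untested is meant among the compounds shown, and "the series" means these compounds.

Compound 3 `CN1CCN(CCCCn2c3c(c4ccccc42)C(=O)c2c[n+]([O-])c4ccccc4c2C3=O)CC1` gives 100 nM in a toxicity assay on HEK-293T cells (Homo sapiens) for cytotoxicity, read by MTT assay, with a stated time of 72 h (on this read-out higher numbers stand for weaker inhibition and lower numbers for stronger inhibition), the second highest of the three numbers. Compound 1 `CN(C)CCCCCn1c2c(c3ccccc31)C(=O)c1c[n+]([O-])c3ccccc3c1C2=O` gives 70 nM, and a 1.4-fold higher number from compound 1 to compound 3 (0.15 log units; within the scatter) separates the two; compound 2 `O=C1c2c[n+]([O-])c3ccccc3c2C(=O)c2c1c1ccccc1n2Cc1cn(C[C@H](O)CO)nn1` gives 8880 nM, and an 89-fold lower number from compound 2 to compound 3 (1.95 log units; beyond the scatter) is the widest gap in the set. Compound 4 `CN1CCN(CCCCCCn2c3c(c4ccccc42)C(=O)c2c[n+]([O-])c4ccccc4c2C3=O)CC1` carries 2-(4-methylpiperazin-1-yl)ethyl in place of 4-methylpiperazin-1-yl on a saturated chain carbon, four bonds along the chain from an aromatic nitrogen. Among the measured compounds shown here, no measured step alters the chain alone. The closest comparison, a 1.4-fold higher number from compound 1 to compound 3 (0.15 log units; within the scatter), shows that exchanging the end of the chain left the number inside the scatter, whereas the large movements a 130-fold higher number from compound 1 to compound 2 (2.10 log units; beyond the scatter) and an 89-fold lower number from compound 2 to compound 3 (1.95 log units; beyond the scatter) concern the triazole and do not bear on this change. The expected step is therefore no change at the digits printed from compound 3 to compound 4 (within the scatter), nothing beyond the scatter. Compound 4 is estimated at 100 nM, range 40 nM to 250 nM.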

Compound 4, half-maximal inhibitory concentration: 5800 nM
Compound 4: the middle estimate sits 58-fold (1.76 log units) below what was measured, and the stated range ends below it.
By their numbers in this assay, from the lowest: compounds 1 and 3 (each within the scatter of the next); then compounds 4 and 2 (each within the scatter of the next).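

Lengthening the chain alone, with 2-(4-methylpiperazin-1-yl)ethyl in place of 4-methylpiperazin-1-yl, is a large change in this assay (a 58-fold higher number from compound 3 to compound 4 (1.76 log units; beyond the scatter)), so this position responds to chain length, whereas the earlier exchange of chain end did not move the number beyond the scatter. Compound 4 also stands far from the dimethylamino compound (an 83-fold higher number from compound 1 to compound 4 (1.92 log units; beyond the scatter)), yet within the scatter of the triazole compound (a 1.5-fold lower number from compound 2 to compound 4 (0.18 log units; within the scatter)). Nothing available accounts for the step.

Open: whether a chain of intermediate length ending in 4-methylpiperazin-1-yl lies nearer compound 3 or compound 4, and whether a morpholine on the longer chain behaves alike.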